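From Compound 2 to Compound 3: One Group Exchanged

The compounds below may be only part of what the source reports. "The series", "measured", "known", "first", "only" and "open" are said of these compounds alone.

- Compound 1 `CC(C)C(c1cnc(N)s1)c1ccc(-c2ccc3cccc(F)c3c2)[nH]c1=O`: 0.0983 h
- Compound 2 `CC(C)C(/C=C1/CCNC1=O)c1ccc(-c2ccc3cccc(F)c3c2)[nH]c1=O`: 0.06 h

In an ADME assay on microsomes from liver (Rattus norvegicus) for metabolic stability (on this read-out higher numbers stand for a longer-lived compound and lower numbers for a shorter-lived compound), compound 2 gives 0.06 h and compound 1 gives 0.0983 h. Going by the values given here, these two values lie within the scatter of each other, so compound 2 stands level with the only compound available for comparison.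

Compound 3 `Cc1c[nH]c(C(c2ccc(-c3ccc4cccc(F)c4c3)[nH]c2=O)C(C)C)n1` differs from compound 2 by a group of 6 heavy atoms (4 carbon, 2 nitrogen; one five-membered aromatic ring with 2 hetero atoms) in place of a group of 7 heavy atoms (5 carbon, 1 nitrogen, 1 oxygen; one five-membered non-aromatic ring with 1 hetero atom), on a saturated chain carbon bound to an aromatic carbon and a saturated chain carbon. The entering 4-methyl-1H-imidazol-2-yl group, like the group in compound 1, has one five-membered aromatic ring with 2 hetero atoms. Among the compounds with values here, one measured step bears on this exchange: a 1.6-fold lower number from compound 1 to compound 2 (0.21 log units; within the scatter). It replaced one group at the same place and stayed within the scatter, so no change beyond the scatter is expected here. The expected step is a 1.3-fold higher number from compound 2 to compound 3 (0.12 log units; within the scatter). For compound 3, the estimated half-life is 0.08 h, with an expected range of 0.04 h to 0.16 h.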

Compound 3, half-life: < 0.0667 h
Compound 3: a limit, no number; the forecaster's own chance of this, stated with the estimate: 5%; middle value at least 1.1-fold (0.07 log units) from the limit.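

In this assay compound 3 gives < 0.0667 h, which is a limit of the assay and not a number. The step from compound 2 therefore cannot be read, because the value of compound 3 stands at that limit: the limit of < 0.0667 h in this assay, at which 1 of the 3 values shown sits. From the compounds shown here alone, the comparison with the other five-membered aromatic ring with 2 hetero atoms can be read in part, as 4-methyl-1H-imidazol-2-yl in place of 2-amino-1,3-thiazol-5-yl gives an at least 1.4-fold lower number from compound 1 to compound 3 (0.16 log units; that floor lies within the scatter), so this exchange brings no gain in half-life, though its true size remains unknown.

Going by these compounds, how far compound 3 lies under its limit stays open. So does whether a group without a ring, such as an amine or a carboxylic acid, on this saturated chain carbon would give a longer half-life.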